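A few compounds are considered here, and "the series" means these few. Any claim that something is new, unique, unknown or untested is made for them only; others in the source may bear on it.

Measured so far in an assay on isolated protein for agonist activity at prostaglandin E2 receptor EP2 subtype (Homo sapiens); on this read-out lower numbers stand for an effect already at smaller amounts and higher numbers for an effect only at larger amounts of compound:
Compound 1, `CCOCCC1([C@H](O)/C=C/[C@H]2COC(=O)N2CCSc2nc(C(=O)O)cs2)CCC1`: 29 nM
Compound 2, `COCCCC1([C@H](O)/C=C/[C@H]2COC(=O)N2CCSc2nc(C(=O)O)cs2)CCC1`: 18 nM
Compound 3, `CCCCC1([C@H](O)/C=C/[C@H]2COC(=O)N2CCSc2nc(C(=O)O)cs2)CCC1`: 2.9 nM

Compound 3 gives the lowest number of the three. The two steps into it are a 10-fold lower number from compound 1 to compound 3 (1.00 log units; beyond the scatter) and a 6.2-fold lower number from compound 2 to compound 3 (0.79 log units; beyond the scatter); both are beyond the scatter, so compound 3 is the most potent of the measured compounds in this assay. The step between the other two, a 1.6-fold lower number from compound 1 to compound 2 (0.21 log units; within the scatter), stays within the scatter.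

Compound 4, `CC#CCC1([C@H](O)/C=C/[C@H]2COC(=O)N2CCSc2nc(C(=O)O)cs2)CCC1`, is not yet measured. It differs from compound 3 by prop-1-yn-1-yl in place of propyl on a saturated chain carbon bound to a saturated ring carbon. Going by the values given here, no measured step touches this kind of change: the steps known so far exchange an ether-containing chain for an all-carbon one, whereas here the all-carbon chain of compound 3 is kept and only a triple bond is introduced. Those steps, a 10-fold lower number from compound 1 to compound 3 (1.00 log units; beyond the scatter) and a 6.2-fold lower number from compound 2 to compound 3 (0.79 log units; beyond the scatter), were modest; the present change is of a different kind, so no step beyond the scatter is expected in this assay, with wider uncertainty than the scatter alone. Compound 4 is therefore estimated at 4 nM, range 1.5 nM to 12 nM, an expected step of a 1.4-fold higher number from compound 3 to compound 4 (0.14 log units; within the scatter).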

Compound 4, half-maximal effective concentration: 21 nM
Beside the measured number, compound 4's estimate is 5.3-fold (0.72 log units) below it; the whole stated range lies below it.
By their numbers in this assay, from the lowest: compound 3; then compounds 2, 4 and 1 (each within the scatter of the next).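

At this place, on a saturated chain carbon bound to a saturated ring carbon, an all-carbon chain is not enough for the low number of compound 3 in this assay: prop-1-yn-1-yl in place of propyl gives a 7.2-fold higher number from compound 3 to compound 4 (0.86 log units; beyond the scatter), so a triple bond alone changes the result here. The alkyne chain sits level with both ether-containing chains, with a 1.2-fold higher number from compound 2 to compound 4 (0.07 log units; within the scatter) and a 1.4-fold lower number from compound 1 to compound 4 (0.14 log units; within the scatter), which leaves compound 3 alone apart from the other three compounds. Nothing measured here accounts for this change.

Still open, as far as these compounds go, is whether prop-1-en-1-yl at this place would read with propyl or with prop-1-yn-1-yl. Also open, from the compounds shown here alone, is whether a longer chain, such as pentyl in place of propyl, would keep the number of compound 3.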